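Carbamate ester variation and maximal response at the receptor

This account rests on a few compounds, and the source may have more. Where it says the series, first, only, none or still open, it means among the compounds named here.

Compound 1, `Cc1nc(S(C)(=O)=O)ccc1Oc1ncnc(OC2CCN(C(=O)OC3CCC3)CC2)c1F`, gives 81% in a functional assay on isolated protein for inhibition of Glucose-dependent insulinotropic receptor (Rattus norvegicus), read by HTRF and cAMP accumulation; a lower number here means a smaller maximal response, a higher number a larger maximal response. Compound 2, `Cc1nc(S(C)(=O)=O)ccc1Oc1ncnc(OC2CCN(C(=O)OC(C)(C)C(F)(F)F)CC2)c1F`, gives 79% in this assay. Compound 3, `Cc1nc(S(C)(=O)=O)ccc1Oc1ncnc(OC2CCN(C(=O)OC3COC3)CC2)c1F`, gives 66% in this assay.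

Among these three measured compounds, compound 3 stands lowest: its nearest neighbour is compound 2, the step of a number 13 percentage points lower from compound 2 to compound 3 (beyond the scatter), and the furthest is compound 1, the step of a number 15 percentage points lower from compound 1 to compound 3 (beyond the scatter). Both steps lie beyond the scatter. Compound 1 and compound 2 themselves differ only by a number 2 percentage points lower from compound 1 to compound 2 (within the scatter), which is within the scatter.

Compound 4, `Cc1nc(S(C)(=O)=O)ccc1Oc1ncnc(OC2CCN(C(=O)OC3(C(F)(F)F)CCC3)CC2)c1F`, differs from compound 3 in one place: 1-(trifluoromethyl)cyclobutyl in place of oxetan-3-yl on an oxygen next to a carbonyl group. The entering group carries both a four-membered ring of carbon only, as in the cyclobutyl of compound 1, and a trifluoromethyl, as in the group of compound 2. The two measured steps that bear on this change are the losses going to the oxetan-3-yl ester, a number 15 percentage points lower from compound 1 to compound 3 (beyond the scatter) and a number 13 percentage points lower from compound 2 to compound 3 (beyond the scatter). Reversing that change is therefore expected to raise the maximal response by a comparable amount, beyond the scatter. Compound 4 is estimated at 80%, between 70% and 90%, an expected step of a number 14 percentage points higher from compound 3 to compound 4 (beyond the scatter).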

Compound 4, largest response reached (reported as efficacy), in percent of the reference or control that the assay uses: 82%
Beside the measured number, compound 4's estimate is 2 percentage points below it; the range from low to high includes it.
By their numbers in this assay, from the lowest: compound 3; then compounds 2, 1 and 4 (each within the scatter of the next).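

Replacing the oxetan-3-yl with 1-(trifluoromethyl)cyclobutyl on this oxygen gives a number 16 percentage points higher from compound 3 to compound 4 (beyond the scatter) in this assay, so the entering group, with its four-membered ring of carbon only and its trifluoromethyl together, carries none of the loss seen with the oxetan-3-yl. The trifluoromethyl in place of hydrogen on the saturated ring carbon can now be read on its own, as a number 1 percentage points higher from compound 1 to compound 4 (within the scatter), and the swap from the open 1-methyl-1-(trifluoromethyl)ethyl to the ring gives a number 3 percentage points higher from compound 2 to compound 4 (within the scatter), so neither change separates these esters. Among the four compounds, the cyclobutyl, 1-methyl-1-(trifluoromethyl)ethyl and 1-(trifluoromethyl)cyclobutyl esters therefore stand together within the scatter, and only the oxetan-3-yl ester of compound 3 stands apart.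

On these data alone, it remains open whether other groups on this oxygen, such as tetrahydrofuran-3-yl, a cyclobutyl bearing a hydroxyl or a longer chain such as n-butyl, would follow compound 3 or the other three. Nothing shown here accounts for why the oxetan-3-yl ester differs from the others.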